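The compounds below may be only part of what the source reports. "The series", "measured", "known", "first", "only" and "open" are said of these compounds alone.

In an assay on frontal cortex for displacement of a labelled ligand from corticotropin-releasing factor receptor 1 (Rattus norvegicus), with a stated time of 2 h (on this read-out higher numbers stand for weaker inhibition and lower numbers for stronger inhibition), the measured compounds are: compound 1 `COc1nc(C)c(Nc2nc(Cl)cn([C@H](CO)C3CC3)c2=O)cc1C` with 88 nM; compound 2 `COc1nc(C)c(Nc2nc(Cl)cn([C@H](COC(=O)c3ccccn3)C3CC3)c2=O)cc1C` with 67 nM; compound 3 `COc1nc(C)c(Nc2nc(Cl)cn([C@H](COC(=O)Nc3cccnc3)C3CC3)c2=O)cc1C` with 10 nM.

Compound 3 has the lowest number of the three, with a 6.7-fold lower number from compound 2 to compound 3 (0.83 log units; beyond the scatter) and an 8.8-fold lower number from compound 1 to compound 3 (0.94 log units; beyond the scatter), both beyond the scatter. Compound 4 `COc1nc(C)c(Nc2nc(Cl)cn([C@H](COc3ccc(C(F)(F)F)cn3)C3CC3)c2=O)cc1C` differs from compound 3 by 5-(trifluoromethyl)pyridin-2-yl in place of (pyridin-3-yl)carbamoyl on an oxygen on a saturated carbon. For the measured compounds named here, the steps that bear on this are an 8.8-fold lower number from compound 1 to compound 3 (0.94 log units; beyond the scatter) and a 6.7-fold lower number from compound 2 to compound 3 (0.83 log units; beyond the scatter), which show that the (pyridin-3-yl)carbamoyl group accounts for the gain of compound 3, while a 1.3-fold lower number from compound 1 to compound 2 (0.12 log units; within the scatter) stayed within the scatter. Removing that group is therefore expected to cost part of the gain, giving an estimated 4.5-fold higher number from compound 3 to compound 4 (0.65 log units; beyond the scatter) in this assay. Compound 4 is estimated at 45 nM, within a range of 12 nM to 180 nM.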

Compound 4, half-maximal inhibitory concentration: 1.6 nM
Compound 4: middle estimate off by 28-fold (1.45 log units), on the high side; the whole stated range lies above it.
By their numbers in this assay, from the lowest: compound 4; then compound 3; then compounds 2 and 1 (each within the scatter of the next).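

On the oxygen on a saturated carbon, the carbamoyl link with its hydrogen-bond donor is not needed for a low number in this assay: 5-(trifluoromethyl)pyridin-2-yl, which has no such donor, gives a 6.3-fold lower number from compound 3 to compound 4 (0.80 log units; beyond the scatter). The same group also gives a 42-fold lower number from compound 2 to compound 4 (1.62 log units; beyond the scatter) and a 55-fold lower number from compound 1 to compound 4 (1.74 log units; beyond the scatter), so within these compounds a ring joined directly to this oxygen outperforms both the carbonyl-linked groups and the free hydroxyl. Nothing available explains why this replacement lowers the number.

The compounds shown do not separate the contribution of the trifluoromethyl group from that of the pyridine ring joined through the oxygen. Plain pyridin-2-yl, or the same ring with methyl or chlorine in place of trifluoromethyl, would address that question.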